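What one methoxy group contributes to cell inhibition

This account rests on a few compounds, and the source may have more. Where it says the series, first, only, none or still open, it means among the compounds named here.

Measured values in a functional assay on DLD-1 cells (Homo sapiens) for inhibition, with a stated time of 48 h; on this read-out lower numbers stand for stronger inhibition and higher numbers for weaker inhibition:

Compound 1, `COc1cc2oc(/C=C/[S+](C)[O-])cc(=O)c2cc1O`: > 10000 nM
Compound 2, `COc1ccc2c(=O)cc(/C=C/[S+](C)[O-])oc2c1OC`: 3300 nM
Compound 3, `C[S+]([O-])/C=C/c1cc(=O)c2cc(O)ccc2o1`: > 10000 nM

Compound 1 gives > 10000 nM, which is a limit of the assay rather than a number. Compound 3 gives > 10000 nM, which is likewise a limit. Compound 2 is the only one of the three with a number, giving 3300 nM in this assay.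

Compound 3 differs from compound 1 by hydrogen in place of methoxy on an aromatic carbon
The size of the step that the two limits leave unreadable from compound 1 to compound 3 cannot be read because both values sit at the limit of > 10000 nM in this assay, at which 2 of the 3 values shown sit. Compound 2 has a different core from compound 1; the difference between the two cores is not broken down here.

Compound 4, `COc1ccc2c(=O)cc(/C=C/[S+](C)[O-])oc2c1`, has not yet been measured. It differs from compound 2 by hydrogen in place of methoxy on an aromatic carbon
For the measured compounds named here, this is the same kind of change as the one from compound 1 to compound 3, but the surroundings differ: in compound 2 the carbon is ortho to a fused ring, ortho to a methoxy group and meta to a fused ring, whereas in compound 1 it is ortho to a hydroxy group, meta to a fused ring and para to a fused ring.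

The measured pair offers no readable step to lean on, so the expectation rests on compound 2 alone, with its value 3300 nM as the anchor. The change from compound 2 to compound 4 is expected to produce a step of a 1.8-fold higher number from compound 2 to compound 4 (0.26 log units; within the scatter) in this assay, with a real chance that only a limit is reported. Compound 4 is estimated at 6000 nM, with a likely range from 2000 nM to 20000 nM.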

Compound 4, half-maximal inhibitory concentration: 1800 nM
Beside the measured number, compound 4's estimate is 3.3-fold (0.52 log units) above it; the measured number lies below the stated range.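

In this assay, hydrogen in place of methoxy gives a 1.8-fold lower number from compound 2 to compound 4 (0.26 log units; within the scatter), so on this core the methoxy group can be lost without a change that stands out from the scatter. Whether that result carries over to the core of compound 1 stays unknown, because the matching step, to compound 3, cannot be read, with both of its values being limits of the assay rather than numbers: the limit of > 10000 nM in this assay, at which 2 of the 4 values shown sit.

For the compounds shown here, the one readable step beyond the scatter, hydrogen in place of hydroxy, gives an at least 5.5-fold lower number from compound 1 to compound 4 (0.74 log units; beyond the scatter), but this is a different change and it starts from a limit of the assay rather than a number, so it says nothing about how the methoxy swap behaves on either core.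

Only hydrogen, hydroxy and methoxy appear on the aromatic ring in the compounds shown, so how an ethoxy group, a chlorine atom or an amine there would read in this assay stays open. All four compounds also keep the same sulfur-bearing side chain, which leaves open what a carboxylic acid or an amide in its place would do.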